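What methoxy may do to compound 3

The source may report more compounds than this note shows. Statements on the series, on what has been measured and on what is new or still open speak of the compounds shown alone.

Compound 1 `Cc1ccc(/C=C/C(=O)Oc2ccc(/C=C3\CCCC(CN(C)C)C3=O)cc2)cc1` gives 2430 nM
Compound 2 `CN(C)CC1CCC/C(=C\c2ccc(OC(=O)/C=C/c3ccc(Br)cc3)cc2)C1=O` gives 1780 nM
Compound 3 `CN(C)CC1CCC/C(=C\c2ccc(OC(=O)c3ccccc3)cc2)C1=O` gives 23400 nM

In a functional assay on L1210 cells (Mus musculus) (a lower number here means a stronger inhibitor, a higher number a weaker inhibitor), compound 3 (23400 nM) has the highest number of the three. Its steps to both others lie beyond the scatter, so it is the weakest inhibitor measured so far. The next structure, compound 4 `COc1ccc(C(=O)Oc2ccc(/C=C3\CCCC(CN(C)C)C3=O)cc2)cc1`, keeps all of compound 3 but has methoxy in place of hydrogen on an aromatic carbon, para to a large group (methoxy in place of hydrogen on an aromatic carbon).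

Among the measured compounds shown here, no measured pair makes this exact change. The nearest evidence is a 1.4-fold lower number from compound 1 to compound 2 (0.14 log units; within the scatter) with bromo in place of methyl on an aromatic carbon, and that step lies within the scatter. Two other steps are larger, a 9.6-fold higher number from compound 1 to compound 3 (0.98 log units; beyond the scatter) and a 13-fold higher number from compound 2 to compound 3 (1.12 log units; beyond the scatter), but each swaps a whole substituted ethenyl arm for phenyl, which is a much bigger edit than the one here. They therefore say little about adding methoxy.

Only a small step is expected in this assay, with no firm direction. The estimated step is a 1.2-fold lower number from compound 3 to compound 4 (0.07 log units; within the scatter) and stays within the scatter. Compound 4 is expected at 20000 nM (estimated range 8000 nM to 45000 nM).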

Compound 4, half-maximal inhibitory concentration: 2870 nM
Beside the measured number, compound 4's estimate is 7.0-fold (0.84 log units) above it, and the stated range ends above it.
By their numbers in this assay, from the lowest: compounds 2, 1 and 4 (each within the scatter of the next); then compound 3.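

In this assay, the change from phenyl to 4-methoxyphenyl, an addition of only 2 heavy atoms, gives an 8.2-fold lower number from compound 3 to compound 4 (0.91 log units; beyond the scatter) and so shows that this aromatic carbon, para to a large group, is far from indifferent to what it carries. The earlier compounds linked the weakness of compound 3 only to the loss of a whole substituted ethenyl arm, but a single methoxy now closes that gap: there is a 1.6-fold higher number from compound 2 to compound 4 (0.21 log units; within the scatter) and a 1.2-fold higher number from compound 1 to compound 4 (0.07 log units; within the scatter) and both steps lie within the scatter, so among these compounds the ethenyl arm is not needed to reach this level, and compound 3 alone stands apart as the weakest. Nothing available here explains why methoxy has this effect.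

The compounds shown leave open whether the gain belongs to methoxy itself or would come with any group at this place, such as a chloro group, a hydroxyl or an amine. They also leave open whether methoxy in place of the methyl of compound 1 would change its number at all.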